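A Branched Three-Carbon Chain Replaces the Methoxyethyl Group

The source may hold more compounds than are shown below. What is called first, only, known or untested is meant among the compounds shown, and "the series" means these compounds.

Measured so far:
Compound 1 `CCCCNc1nnc(SCC(=O)N(Cc2cccc([N+](=O)[O-])c2)c2ccc(F)cc2)s1` gives 33.6% in an assay on isolated protein for inhibition of Amine oxidase [flavin-containing] A (Homo sapiens), read by fluorescence and Amplex Red, with a stated time of 30 min, tested at 0.1 uM; on this read-out higher numbers stand for a stronger effect at the one concentration tested and lower numbers for a weaker effect.
Compound 2 `CCCNc1nnc(SCC(=O)N(Cc2cccc([N+](=O)[O-])c2)c2ccc(F)cc2)s1` gives 45.2% in this assay.
Compound 3 `COCCNc1nnc(SCC(=O)N(Cc2cccc([N+](=O)[O-])c2)c2ccc(F)cc2)s1` gives 61.1% in this assay.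

Compound 3 stands highest of the three numbers: the step of a number 15.9 percentage points higher from compound 2 to compound 3 (beyond the scatter) and the step of a number 27.5 percentage points higher from compound 1 to compound 3 (beyond the scatter) both lie beyond the scatter. Compound 4 `CC(C)Nc1nnc(SCC(=O)N(Cc2cccc([N+](=O)[O-])c2)c2ccc(F)cc2)s1` is the next compound and differs from compound 3 in one place: isopropyl in place of 2-methoxyethyl on a nitrogen on an aromatic ring.

For the measured compounds named here, two measured steps bear on this change. Step a number 15.9 percentage points higher from compound 2 to compound 3 (beyond the scatter) shows what adding a methoxy group in place of a methyl did, and step a number 11.6 percentage points higher from compound 1 to compound 2 (beyond the scatter) shows what shortening the chain by one carbon did. Compound 4 carries an isopropyl group, with three carbons and no hydrogen-bond acceptor, which matches the count for compound 2 rather than for compound 3. The most relevant comparison is therefore the reverse of the step from compound 2 to compound 3, so a modest fall beyond the scatter is expected: a number 18.1 percentage points lower from compound 3 to compound 4 (beyond the scatter). Compound 4 is estimated at 43% in this assay, with an expected range from 28% to 58%.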

Compound 4, a percentage reported as inhibition, at one concentration (the size of the read-out at that concentration, not a potency): 43%
For compound 4 middle estimate and measured number coincide at the digits printed, within the range that was stated.
By their numbers in this assay, from the lowest: compounds 1, 4 and 2 (each within the scatter of the next, the first and the last beyond it); then compound 3.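

For the compounds shown here, the fall seen with isopropyl in place of 2-methoxyethyl, a number 18.1 percentage points lower from compound 3 to compound 4 (beyond the scatter) in this assay, means that compound 3, the only compound here whose chain holds an oxygen, now stands beyond the scatter from all three all-carbon chains. Branching shows no readable effect at this nitrogen: with isopropyl in place of propyl there is a number 2.2 percentage points lower from compound 2 to compound 4 (within the scatter), and with isopropyl in place of butyl there is a number 9.4 percentage points higher from compound 1 to compound 4 (within the scatter), so compound 4 cannot be ordered against either straight-chain compound, even though those two differ from each other beyond the scatter. Nothing available explains why the chain holding an oxygen stands apart from the others.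

On these data alone, it remains open whether a 2-hydroxyethyl or a 3-methoxypropyl chain on this nitrogen would match compound 3, and whether a cyclopropyl group would read like isopropyl. As far as these compounds go, all four compounds also share the same remaining structure and were read at one concentration, so how these differences would translate into potency is still unknown.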